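The compounds below may be only part of what the source reports. "The series", "measured", "known", "first", "only" and "open" are said of these compounds alone.

Measured in a functional assay on MCF7 cells (Homo sapiens) for cytotoxicity, read by MTT assay, with a stated time of 72 h; a higher number here means a weaker inhibitor, a lower number a stronger inhibitor:
- compound 1 `Cc1oc2ncnc(Nc3cccc(Br)c3)c2c1C(=O)O`: 68000 nM
- compound 2 `C#Cc1cccc(Nc2ncnc3oc(C)c(C(=O)OCC)c23)c1`: > 1000000 nM (a limit, not a number)

Compound 2 has only a limit to its name: the limit of > 1000000 nM in this assay, at which 1 of the 2 values shown sits. Compound 3 `CCOC(=O)c1c(C)oc2ncnc(Nc3cccc(Br)c3)c12` differs from it in one place: bromo in place of ethynyl on an aromatic carbon. Among the compounds with values here, compound 1 also carries 3-bromophenyl and reads 68000 nM in this assay, but no measured step isolates that group. A shift towards stronger inhibition is expected, of uncertain size, with an estimated at least 4.0-fold lower number from compound 2 to compound 3 (0.60 log units; beyond the scatter). The expected value for compound 3 is 250000 nM (range 50000 nM to 900000 nM).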

Compound 3, half-maximal inhibitory concentration: > 1000000 nM
Compound 3: a limit, no number; the forecaster's own chance of this, stated with the estimate: 35%; at least 4.0-fold (0.60 log units) between middle value and limit.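

In this assay compound 3 gives > 1000000 nM, a limit and not a number. The change from ethynyl to bromo cannot be read, as both ends are limits: the limit of > 1000000 nM in this assay, at which 2 of the 3 values shown sit.

The readable change is ethyl in place of hydrogen on an oxygen next to a carbonyl group, with 3-bromophenyl held constant: an at least 14-fold higher number from compound 1 to compound 3 (1.16 log units; beyond the scatter).

Open, as far as these compounds go, is whether this shift belongs to the ester as such or to its ethyl chain; a primary amide or a methyl ester at this position would separate the two. Also open, from the compounds shown here alone, is how ethynyl reads with the free carboxylic acid in place.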